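This account rests on a few compounds, and the source may have more. Where it says the series, first, only, none or still open, it means among the compounds named here.

In a functional assay on DU-145 cells (Homo sapiens) for antiproliferative activity, read by sulforhodamine B assay, with a stated time of 48 h (on this read-out higher numbers stand for weaker inhibition and lower numbers for stronger inhibition), compound 2 (`C/C=C(\C)C(=O)O[C@H]1C=CC(=O)O[C@H]1COC(=O)[C@H](C)O`) gives 16000 nM and compound 1 (`C/C=C(\C)C(=O)O[C@H]1C=CC(=O)O[C@H]1CCC(=O)[C@H](C)O`) gives 23000 nM, two values within the usual scatter of each other. Compound 3 (`C/C=C(\C)C(=O)O[C@H]1C=CC(=O)O[C@H]1CNC(=O)[C@H](C)O`) carries ((1-hydroxyethyl)carbonyl)amino in place of ((1-hydroxyethyl)carbonyl)oxy on a saturated chain carbon bound to a saturated ring carbon. Going by the values given here, the one measured step at this place (a 1.4-fold lower number from compound 1 to compound 2 (0.16 log units; within the scatter)) lies within the scatter, so no step beyond the scatter is expected in this assay from this change. The expected step is small (a 1.3-fold higher number from compound 2 to compound 3 (0.10 log units; within the scatter)). Compound 3 is estimated at 20000 nM (8000 nM to 50000 nM).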

Compound 3, half-maximal inhibitory concentration: 25000 nM
Estimate against measurement, compound 3: 1.3-fold (0.10 log units) below, and the stated range covers the measured number.
By their numbers in this assay, from the lowest: compounds 2, 1 and 3 (each within the scatter of the next).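

In this assay, the ((1-hydroxyethyl)carbonyl)amino group gives a 1.6-fold higher number from compound 2 to compound 3 (0.19 log units; within the scatter) and a 1.1-fold higher number from compound 1 to compound 3 (0.04 log units; within the scatter), so all three steps among these compounds now lie within the scatter. On a saturated chain carbon bound to a saturated ring carbon, methyl, oxy and amino versions of this group therefore cannot be told apart by this read-out, even with the extra hydrogen-bond donor of the amino version. No supporting evidence bears on this result. As far as these compounds go, whether a carboxylic acid, an amine or a longer chain at this place would move the number beyond the scatter remains open.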